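A few compounds are considered here, and "the series" means these few. Any claim that something is new, unique, unknown or untested is made for them only; others in the source may bear on it.

Values in an ADME assay on HEK293 cells (Homo sapiens) for cytotoxicity, with a stated time of 6 h; a lower number here means that less compound is tolerated, a higher number that more compound is tolerated:
- Compound 1 `CCCCNc1nc(N)nc2cccc(OCCOC)c12`: 10000 nM
- Compound 2 `CCCCNc1nc(N)nc2cccc(C(=O)NC(C)C)c12`: > 25000 nM
- Compound 3 `CCCCNc1nc(N)nc2cccc(C(=O)N(C)Cc3ccccc3)c12`: not yet measured

Compound 2 gives > 25000 nM in this assay, which is a limit of the assay and not a number. As far as these compounds go, compound 2 therefore stands at the limit of > 25000 nM in this assay, at which 1 of the 2 values shown sits, and its true value is unknown.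

Compound 3 keeps the shared core and the carbonyl but has benzyl(methyl)amino in place of isopropylamino on a carbonyl carbon.

Going by the values given here, only one measured step is available, an at least 2.5-fold higher number from compound 1 to compound 2 (0.39 log units; beyond the scatter). It came from isopropylcarbamoyl in place of 2-methoxyethoxy on an aromatic carbon. That step shows that a change in this substituent can move the number, but it is a different change and gives only indirect guidance. Compound 1 at 10000 nM shows that a measurable number is possible in this series, so a modest move towards lower numbers is expected, with real doubt about its direction and size. The expected step is an at least 1.2-fold lower number from compound 2 to compound 3 (0.09 log units; that floor lies within the scatter). For compound 3 the estimated value is 20000 nM, with an expected range from 8000 nM to 40000 nM.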

Compound 3, half-maximal cytotoxic concentration: > 25000 nM
Compound 3: only a limit was reported; the forecaster's own chance of this, stated with the estimate: 45%; middle value at least 1.2-fold (0.09 log units) from the limit.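

Compound 2 and compound 3 both give a limit of the assay and not a number, so no step can be read between them: the limit of > 25000 nM in this assay, at which 2 of the 3 values shown sit.

As far as these compounds go, the true values of compound 2 and compound 3 stay open, and so does whether benzyl(methyl)amino or isopropylamino on the carbonyl carbon gives the higher number.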